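The compounds below may be only part of what the source reports. "The series", "measured", "known", "first", "only" and "open" are said of these compounds alone.

Measured compounds:
Compound 1 `CC(C)(C)c1ccc(C(=O)NCc2ccc(N)cc2Cl)cc1` gives 40 nM in an assay on HeLa cells for agonist activity at Bile acid receptor (Homo sapiens), read by a luciferase reporter, with a stated time of 24 h; a higher number here means that more compound is needed for the effect, a lower number that less compound is needed.
Compound 2 `CCS(=O)(=O)Nc1ccc(CNC(=O)c2ccc(C(C)(C)C)cc2)c(Cl)c1` gives 500 nM in this assay.

Compound 2 stands at the higher of the two numbers; its nearest neighbour is compound 1, and the step of a 13-fold higher number from compound 1 to compound 2 (1.10 log units; beyond the scatter) is the only one measured. Compound 3 `CC(C)S(=O)(=O)Nc1ccc(CNC(=O)c2ccc(C(C)(C)C)cc2)c(Cl)c1` differs from compound 2 by methyl in place of hydrogen on a saturated chain carbon bound to a saturated chain carbon and a sulfonyl sulfur. For the measured compounds named here, the single measured step concerns the same region, the nitrogen on the aromatic ring, but it tests the entry of the whole ethylsulfonyl group, not a change within its alkyl chain, so it bears on the present step only loosely. Going by the values given here, no measured pair shows what a methyl added on that chain carbon does. The expectation for this assay is therefore a step of no clear direction, within the scatter. Compound 3 is estimated at 500 nM, with a range from 180 nM to 1500 nM, a step of no change at the digits printed from compound 2 to compound 3 (within the scatter) that is expected to stay within the scatter.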

Compound 3, half-maximal effective concentration: 420 nM
Beside the measured number, compound 3's estimate is 1.2-fold (0.08 log units) above it; measured number inside the range.
By their numbers in this assay, from the lowest: compound 1; then compounds 3 and 2 (each within the scatter of the next).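

Exchanging ethyl for isopropyl on the sulfonyl group gives a 1.2-fold lower number from compound 2 to compound 3 (0.08 log units; within the scatter), so in this assay this chain carbon accepts an added methyl without a change beyond the scatter. The large step seen on placing ethylsulfonyl on the aromatic nitrogen also holds with the branched group, at an 11-fold higher number from compound 1 to compound 3 (1.02 log units; beyond the scatter), so among these compounds the two alkylsulfonyl groups stand together, well apart from compound 1 with its free amine. No evidence is available that explains either step.

The compounds shown leave open whether a methylsulfonyl or an acetyl group on that nitrogen would stand with compounds 2 and 3 or nearer to compound 1. They also leave open whether a longer chain or a phenyl group on the sulfonyl would stay within the scatter of these two.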